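The source may hold more compounds than are shown below. What is called first, only, known or untested is meant among the compounds shown, and "the series" means these compounds.

Measured in a functional assay on MDA-MB-435 cells (Homo sapiens) for inhibition, read by MTT assay, with a stated time of 72 h; a higher number here means a weaker inhibitor, a lower number a stronger inhibitor:
Compound 1 `COC(=O)c1cc(-c2ccc(-c3ccc(O)cc3)c(OC)c2OC)ccc1O`: 44800 nM
Compound 2 `COc1ccc(-c2ccc(-c3ccc(C(=O)O)cc3)c(OC)c2OC)cc1OC`: > 100000 nM
Compound 3 `COc1ccc(-c2ccc(-c3ccc(OC)cc3)c(OC(C)=O)c2OC(C)=O)cc1`: 96800 nM

Compound 2 has no numerical value in this assay, only the limit > 100000 nM. The other two compounds give numbers, compound 1 at 44800 nM and compound 3 at 96800 nM, and both are weak inhibitors.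

Compound 4 `COc1ccc(-c2cccc(OC)c2OC)cc1OC` follows from compound 2 through a single change: hydrogen in place of 4-carboxyphenyl on an aromatic carbon. Hydrogen stands in place of 4-carboxyphenyl on an aromatic carbon, ortho to a methoxy group, meta to a methoxy group and para to a large group.

Within the data shown here, no measured pair isolates a change of this kind, so the expectation rests on the weak values of compound 1 at 44800 nM and compound 3 at 96800 nM. No step beyond the usual scatter is expected, and compound 4 may also reach the limit of this assay. The estimated change is an at least 1.1-fold lower number from compound 2 to compound 4 (0.04 log units; that floor lies within the scatter). For compound 4 the expected value is 90000 nM, with an estimated range of 30000 nM to 200000 nM.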

Compound 4, half-maximal inhibitory concentration: 23100 nM
Estimate against measurement, compound 4: 3.9-fold (0.59 log units) above; the measured number lies below the stated range.
By their numbers in this assay, from the lowest: compounds 4 and 1 (each within the scatter of the next); then compound 3. At a limit, above all of these: compound 2.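

In this assay, hydrogen in place of 4-carboxyphenyl on this aromatic carbon gives an at least 4.3-fold lower number from compound 2 to compound 4 (0.63 log units; beyond the scatter). The 4-carboxyphenyl group is therefore not required at this position for the inhibition seen here, and without it compound 4 gives a number, 23100 nM, though still that of a weak inhibitor. Compound 2 stands at a limit of the assay, so the step is only a floor and its full size cannot be read: the limit of > 100000 nM in this assay, at which 1 of the 4 values shown sits.

The compounds shown leave open whether the carboxylic acid or the phenyl ring that carries it accounts for the step, which an unsubstituted phenyl or a 4-carbamoylphenyl group at this position would help to separate. They also leave open whether a small group there, such as an amine or a hydroxyl, would give a stronger or a weaker inhibitor than compound 4.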